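A few compounds are considered here, and "the series" means these few. Any claim that something is new, unique, unknown or untested is made for them only; others in the source may bear on it.

Measured so far:
- Compound 1, `Nc1nn(C(=O)Nc2ccc(Cc3ccccc3)cc2)c2ccccc12`: 92000 nM
- Compound 2, `Nc1nn(C(=O)Nc2ccc(Cc3ccccc3)cc2)c2ccc(Cl)cc12`: 97600 nM

Compound 2 gives the highest of the two numbers measured in a functional assay on EKVX cells (Homo sapiens) for antiproliferative activity, read by sulforhodamine B assay, with a stated time of 48 h (a lower number here means a stronger inhibitor of growth, a higher number a weaker inhibitor of growth), but the distance to compound 1 is small: a 1.1-fold higher number from compound 1 to compound 2 (0.03 log units; within the scatter). The two compounds therefore cannot be told apart on these numbers.

The next compound, compound 3 `Nc1ccc2c(c1)c(N)nn2C(=O)Nc1ccc(Cc2ccccc2)cc1`, differs from compound 2 at the same position that distinguishes compound 1 from compound 2: amino in place of chloro on an aromatic carbon. Among the compounds with values here, no measured step involves an amino group at this place; the only step that bears on it is the change from hydrogen to chloro, which left the number within the scatter. That one step suggests this position tolerates a change without a large effect, but it says nothing specific about an amino group, so the expectation for compound 3 must stay wide.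

Compound 3 is expected to give about 90000 nM in this assay, within a range of 30000 nM to 250000 nM, which means an expected step of a 1.1-fold lower number from compound 2 to compound 3 (0.04 log units; within the scatter), no direction beyond the scatter being favoured.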

Compound 3, concentration for total growth inhibition: 36700 nM
The estimate for compound 3 lay 2.5-fold (0.39 log units) above the measured number; the measured number falls inside the stated range.
By their numbers in this assay, from the lowest: compound 3; then compounds 1 and 2 (each within the scatter of the next).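

Until now this position on the shared core had shown no measurable response, as the change from hydrogen to chloro stayed within the scatter, but in this assay an amino group gives a 2.7-fold lower number from compound 2 to compound 3 (0.42 log units; beyond the scatter) and a 2.5-fold lower number from compound 1 to compound 3 (0.40 log units; beyond the scatter). The position is therefore not indifferent to every group placed on it: both steps are modest but lie beyond the scatter, which makes compound 3 the strongest inhibitor of growth among the three compounds. The amino group adds a hydrogen-bond donor and a hydrogen-bond acceptor by the count, where chloro has neither, yet no measurement available here explains the lower number.

With only hydrogen, chloro and amino shown at this place, it remains open whether the lower number is particular to the amino group or would also appear with a hydroxyl or a methoxy group. The compounds shown also leave open whether adding to the amino group itself, as in methylamino, dimethylamino or acetylamino, would lower the number further, keep it or lose the step.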